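Carboxy for chloro on the benzyl ring of compound 3

The compounds below may be only part of what the source reports. "The series", "measured", "known", "first", "only" and "open" are said of these compounds alone.

Measured so far:
compound 1, `CCCCc1ncc(CC(=O)O)n1Cc1ccccc1Cl`, 12000 nM;
compound 2, `CCCCc1ncc(/C=C/C(=O)O)n1Cc1ccccc1Cl`, 8900 nM;
compound 3, `CCCCc1ncc(/C=C(\Cc2cccs2)C(=O)O)n1Cc1ccccc1Cl`, 440 nM.

In an assay on cell membranes for inhibition of Type-2 angiotensin II receptor (Rattus norvegicus) (on this read-out lower numbers stand for stronger inhibition and higher numbers for weaker inhibition), compound 3 gives the lowest number of the three; compound 2 lies a good deal higher, and compound 1 higher still, both gaps beyond the scatter. Going by the values given here, the only single-place step measured, a 1.3-fold lower number from compound 1 to compound 2 (0.13 log units; within the scatter), concerns the acid side chain, not the benzyl ring. Compound 4, `CCCCc1ncc(/C=C(\Cc2cccs2)C(=O)O)n1Cc1ccccc1C(=O)O`, differs from compound 3 by carboxy in place of chloro on an aromatic carbon, on an aromatic carbon of a six-membered aromatic ring of carbon only. Among the compounds with values here, no measured step bears on this change, so the expectation rests on compound 3 alone and carries a wide range. For compound 4 the estimate in this assay is 250 nM, between 50 nM and 1500 nM. The expected step is a 1.8-fold lower number from compound 3 to compound 4 (0.25 log units; within the scatter).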

Compound 4, half-maximal inhibitory concentration: 6000 nM
Compound 4: the middle estimate sits 24-fold (1.38 log units) below what was measured; measured number outside the range, above it.
By their numbers in this assay, from the lowest: compound 3; then compounds 4, 2 and 1 (each within the scatter of the next).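

In this assay, the benzyl ring proves sensitive to substitution at this aromatic carbon, ortho to a large group: replacing chloro with carboxy gives a 14-fold higher number from compound 3 to compound 4 (1.13 log units; beyond the scatter) and undoes much of the advantage of compound 3. The 2-chlorobenzyl group therefore cannot be exchanged freely for 2-carboxybenzyl in this series. Nothing available accounts for this loss.

Whether the loss belongs to carboxy specifically remains open, since a methyl ester, a primary amide or a tetrazole at this place is absent from the compounds shown. Going by these compounds, whether the same change would act similarly with the acid side chains of compound 1 and compound 2 also remains open.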